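The compounds below may be only part of what the source reports. "The series", "measured", "known", "first", "only" and "open" are said of these compounds alone.

In a functional assay on HeLa cells (Homo sapiens) for antiproliferative activity, read by CCK-8 assay, with a stated time of 72 h (a higher number here means a weaker inhibitor, a lower number a stronger inhibitor), compound 1 (`Cc1cc(Nc2cc(N3CCN(C)CC3)nc(Nc3ccc(S(N)(=O)=O)cc3)n2)n[nH]1`) gives 3060 nM with a 4-sulfamoylphenyl group, compound 2 (`Cc1cc(Nc2cc(N3CCN(C)CC3)nc(Nc3ccc(Cl)cc3)n2)n[nH]1`) gives 619 nM with 4-chlorophenyl in that place, and compound 3 (`COc1cccc(Nc2nc(Nc3cc(C)[nH]n3)cc(N3CCN(C)CC3)n2)c1`) gives 546 nM with 3-methoxyphenyl there. Compound 3 therefore sits level with compound 2 and clearly under compound 1 on these numbers. Compound 4 (`Cc1cc(Nc2cc(N3CCN(C)CC3)nc(Nc3cccc([N+](=O)[O-])c3)n2)n[nH]1`) has not been measured. It differs from compound 3 by nitro in place of methoxy on an aromatic carbon. Within the data shown here, no measured step makes this exact swap, so the nearest guides are changes to the same substituted phenyl group. Moving away from the sulfamoyl compound gave modest steps beyond the scatter (a 4.9-fold lower number from compound 1 to compound 2 (0.69 log units; beyond the scatter) and a 5.6-fold lower number from compound 1 to compound 3 (0.75 log units; beyond the scatter)), while the chloro and methoxy compounds stayed within the scatter of each other (a 1.1-fold lower number from compound 2 to compound 3 (0.05 log units; within the scatter)). Compound 4 is thus expected to stay close to compound 2 and compound 3, perhaps with a slightly higher number. The estimated step is a 1.2-fold higher number from compound 3 to compound 4 (0.08 log units; within the scatter) and it is expected to stay within the scatter. In this assay the estimate for compound 4 is 650 nM with 250 nM to 1700 nM as the expected range.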

Compound 4, half-maximal inhibitory concentration: 1110 nM
Estimate against measurement, compound 4: 1.7-fold (0.23 log units) below, within the range that was stated.
By their numbers in this assay, from the lowest: compounds 3, 2 and 4 (each within the scatter of the next, the first and the last beyond it); then compound 1.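

In this assay, among these compounds, the swap at this place on the phenyl ring gives a 2.0-fold higher number from compound 3 to compound 4 (0.31 log units; beyond the scatter) and is the first step among the compounds without the sulfamoyl group to lie beyond the scatter, though it is only modest. Set against the 4-chlorophenyl group, the 3-nitrophenyl group gives a 1.8-fold higher number from compound 2 to compound 4 (0.25 log units; within the scatter) which lies within the scatter, so the swap is a small change rather than a clear loss, and the step of a 2.8-fold lower number from compound 1 to compound 4 (0.44 log units; beyond the scatter) leaves the sulfamoyl compound still the weakest of the four. Nothing available explains why these groups differ.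

On these data alone, whether an amine or a carboxylic acid at this place would read like compound 1 or like compound 4 stays open. So does the effect of a smaller group such as methyl or nitrile.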